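Trifluoromethylphenyl swap on a fluorinated core

The compounds below may be only part of what the source reports. "The series", "measured", "known", "first", "only" and "open" are said of these compounds alone.

Compound 1 `Cc1ccc(-n2nc(C(=O)Nc3ccc(Oc4ncnc5c4ccn5C)cc3)c(C)cc2=O)cc1` and compound 2 `Cc1cc(=O)n(-c2ccccc2C(F)(F)F)nc1C(=O)Nc1ccc(Oc2ncnc3c2ccn3C)cc1` share a core that compound 3 `Cc1ccc(-n2nc(C(=O)Nc3ccc(Oc4ncnc5c4ccn5C)c(F)c3)c(C)cc2=O)cc1` varies by fluoro in place of hydrogen on an aromatic carbon. In a functional assay on MCF7 cells (Homo sapiens) for cytotoxicity, read by MTT assay, with a stated time of 72 h (on this read-out lower numbers stand for stronger inhibition and higher numbers for weaker inhibition), compound 1 gives 10800 nM and compound 2 gives 7840 nM. For compound 3 this assay reports only a limit, > 60000 nM. Thus the step of an at least 5.5-fold higher number from compound 1 to compound 3 (0.74 log units; beyond the scatter) is read against (the limit of > 60000 nM in this assay, at which 1 of the 3 values shown sits). The change 2-(trifluoromethyl)phenyl in place of 4-methylphenyl on an aromatic nitrogen gave a 1.4-fold lower number from compound 1 to compound 2 (0.14 log units; within the scatter). Compound 4 `Cc1cc(=O)n(-c2ccccc2C(F)(F)F)nc1C(=O)Nc1ccc(Oc2ncnc3c2ccn3C)c(F)c1` carries the same change on the core of compound 3, (2-(trifluoromethyl)phenyl in place of 4-methylphenyl on an aromatic nitrogen). Because compound 3 already sits at the limit of > 60000 nM in this assay, at which 1 of the 3 values shown sits, compound 4 is expected to remain near or above that limit in this assay, a step estimated as a step that the limit leaves unreadable from compound 3 to compound 4, resting on the small step of a 1.4-fold lower number from compound 1 to compound 2 (0.14 log units; within the scatter). Compound 4 is therefore estimated at 80000 nM, between 30000 nM and 200000 nM.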

Compound 4, half-maximal inhibitory concentration: > 60000 nM
Compound 4 was reported as a limit (the forecaster's own chance of this, stated with the estimate: 70%); the middle value lies beyond the limit too.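

Carrying fluoro in place of hydrogen on an aromatic carbon to the second core gives an at least 7.6-fold higher number from compound 2 to compound 4 (0.88 log units; beyond the scatter), the same direction as on the first core in this assay; set side by side: the same change on two cores in this assay, an at least 5.5-fold higher number (0.74 log units; beyond the scatter) from compound 1 to compound 3 and an at least 7.6-fold higher number (0.88 log units; beyond the scatter) from compound 2 to compound 4; the limit leaves it open whether they differ

The swap of 2-(trifluoromethyl)phenyl for 4-methylphenyl cannot be read on the fluorinated core, since compound 3 and compound 4 are both reported only as limits: the limit of > 60000 nM in this assay, at which 2 of the 4 values shown sit.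

Going by these compounds, the direction of the fluoro change therefore holds across these two cores, but its size stays unknown, and nothing shows whether the aryl swap carries over.

Open, on these data alone, is whether a chlorine or a methoxy group in place of the fluoro also gives a higher number in this assay. Also open, as far as these compounds go, is whether an amine or a carboxylic acid on the phenyl ring would bring the fluorinated core back within measurable range.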